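Aryl sulfonamide replacing methylsulfonamide on the shared core

The source may report more compounds than this note shows. Statements on the series, on what has been measured and on what is new or still open speak of the compounds shown alone.

Compound 1 `CC(=O)Nc1cncc(-c2cnc(N)nc2)c1` gives only a limit in an assay on isolated protein for binding affinity to phosphatidylinositol 4,5-bisphosphate 3-kinase catalytic subunit beta isoform (Homo sapiens) (a lower number here means tighter binding, a higher number weaker binding), > 20000 nM. Compound 2 `CS(=O)(=O)Nc1cncc(-c2cnc(N)nc2)c1` gives 5200 nM in this assay, the highest of the two numbers in hand. The step of an at least 3.8-fold lower number from compound 1 to compound 2 (0.58 log units; beyond the scatter) shows that the sulfonamide already lowers the number relative to the acetamide. Compound 3 `Nc1ncc(-c2cncc(NS(=O)(=O)c3cccc(C(F)(F)F)c3)c2)cn1` gives 430 nM, and compound 2 sits well above it. Compound 4 `Cc1ccc(S(=O)(=O)Nc2cncc(-c3cnc(N)nc3)c2)cc1` differs from compound 2 by 4-methylphenyl in place of methyl on a sulfonyl sulfur. For the measured compounds named here, no measured step covers this change directly; the pair compound 2 and compound 3 shows that an aryl sulfonamide can give a much lower number, so the expected step of a 5.8-fold lower number from compound 2 to compound 4 (0.76 log units; beyond the scatter) is taken as a clear drop. For compound 4 the estimate in this assay is 900 nM, within 300 nM to 3000 nM.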

Compound 4, dissociation constant: 100 nM
Beside the measured number, compound 4's estimate is 9.0-fold (0.95 log units) above it; the measured number lies below the stated range.
By their numbers in this assay, from the lowest: compound 4; then compound 3; then compound 2. At a limit, above all of these: compound 1.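

In this assay, for the compounds shown here, 4-methylphenyl in place of methyl on the sulfonyl sulfur gives a 52-fold lower number from compound 2 to compound 4 (1.72 log units; beyond the scatter), the first directly measured step at this position. The sulfonyl sulfur is therefore a place where a single change moves the number by a large step. No measurement shown accounts for this step.

Open, going by these compounds, is whether an aromatic ring is needed on the sulfonyl sulfur, which a cyclohexyl group or a longer alkyl chain there would test. Also open, on these data alone, is how an amine or a carboxylic acid on that ring would read in this assay.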